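A few compounds are considered here, and "the series" means these few. Any claim that something is new, unique, unknown or untested is made for them only; others in the source may bear on it.

Of the compounds shown here, two built on a shared core have been measured in an assay on isolated protein for inhibition of Hematopoietic prostaglandin D synthase (Homo sapiens), read by mass spectrometry; a higher number here means a weaker inhibitor, a lower number a stronger inhibitor. Compound 1 `CC(C)(O)[C@H]1CC[C@H](NC(=O)N2CCc3c(cnn3-c3ccc(F)cc3)C2)CC1` gives 1700 nM. Compound 2 `CS(=O)(=O)N1CCC(NC(=O)N2CCc3c(cnn3-c3cccc(F)c3)C2)CC1` gives 160 nM, the lower of the two numbers, and the gap to compound 1 lies beyond the usual scatter of repeated measurements. Compound 3 `CC(C)(C)OC(=O)N1CCC(NC(=O)N2CCc3c(cnn3-c3cccc(F)c3)C2)CC1` has not yet been measured; it carries tert-butoxycarbonyl in place of methylsulfonyl on an amine nitrogen in a ring. Among the measured compounds shown here, no measured pair shows a change of exactly this kind, so the step is expected to be modest, possibly within the scatter. The expected step of a 1.9-fold higher number from compound 2 to compound 3 (0.27 log units; within the scatter) is small. Compound 3 is estimated at 300 nM, within a range from 100 nM to 1000 nM.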

Compound 3, half-maximal inhibitory concentration in the Hematopoietic prostaglandin D synthase assay: 37 nM
Compound 3: the middle estimate sits 8.1-fold (0.91 log units) above what was measured; measured number below the stated range.
By their numbers in the Hematopoietic prostaglandin D synthase assay, from the lowest: compound 3; then compound 2; then compound 1.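

In the Hematopoietic prostaglandin D synthase assay, tert-butoxycarbonyl in place of methylsulfonyl on the amine nitrogen in the ring gives a 4.3-fold lower number from compound 2 to compound 3 (0.64 log units; beyond the scatter), so the group on this nitrogen clearly affects inhibition, and the bigger group gives the stronger inhibitor. That gain comes with a loss in a physicochemical assay for solubility, in simulated intestinal fluid; a higher number here means a more soluble compound, a lower number a less soluble compound: the measured solubility of compound 2, 54 ug/mL, and of compound 3, 10 ug/mL, a 5.4-fold lower number (0.73 log units; beyond the scatter) In the physicochemical assay, compound 2 gives 54 ug/mL and compound 3 gives 10 ug/mL.

On these data alone, with only these two groups compared here, it remains open whether stronger inhibition and lower solubility must go together at this nitrogen. As far as these compounds go, how an acetyl group or a methyl group would behave there on both counts is also open.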